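A few compounds are considered here, and "the series" means these few. Any claim that something is new, unique, unknown or untested is made for them only; others in the source may bear on it.

Working notes on the amide series sharing the core of compound 1.

For the measured compounds named here, compound 1 `CN(C(=O)CCc1ccccc1)c1ccc2[nH]c(-c3n[nH]c4ccccc34)cc2n1` stands second highest of the three numbers so far in a functional assay on A549 cells (Homo sapiens) for antiproliferative activity, read by MTT assay, with a stated time of 72 h (on this read-out higher numbers stand for weaker inhibition and lower numbers for stronger inhibition), giving 18100 nM. Compound 2 `CN(C(=O)c1ccc(F)cc1)c1ccc2[nH]c(-c3n[nH]c4ccccc34)cc2n1` gives 9650 nM in this assay, and compound 3 `CN(C(=O)c1ccc([N+](=O)[O-])cc1)c1ccc2[nH]c(-c3n[nH]c4ccccc34)cc2n1` gives 34500 nM. Exchanging the phenethyl on the carbonyl carbon for an aryl group moved the read-out little in either direction: a 1.9-fold lower number from compound 1 to compound 2 (0.27 log units; within the scatter), and a 1.9-fold higher number from compound 1 to compound 3 (0.28 log units; within the scatter). Between the two aryl amides the difference is larger, a 3.6-fold higher number from compound 2 to compound 3 (0.55 log units; beyond the scatter), but neither aryl compound is separated from compound 1 beyond the scatter.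

Compound 4 `CN(C(=O)c1ccco1)c1ccc2[nH]c(-c3n[nH]c4ccccc34)cc2n1` carries the change (furan-2-yl in place of phenethyl on a carbonyl carbon). Going by the values given here, no furan-bearing analogue has been measured, so the only steps that bear on it are the two replacements of phenethyl by a six-membered aromatic ring on the same carbonyl carbon, both of which stayed within the scatter. On that basis no step beyond the scatter is expected in this assay from compound 1 to compound 4, and compound 4 is estimated at 15000 nM, with a range from 6000 nM to 40000 nM, which corresponds to an expected step of a 1.2-fold lower number from compound 1 to compound 4 (0.08 log units; within the scatter).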

Compound 4, half-maximal inhibitory concentration: 15500 nM
Estimate against measurement, compound 4: 1.0-fold (0.01 log units) below, and the stated range covers the measured number.
By their numbers in this assay, from the lowest: compounds 2, 4, 1 and 3 (each within the scatter of the next, the first and the last beyond it).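

The furan-2-yl group on this carbonyl carbon gives a read-out in this assay that cannot be separated from those of the larger groups, with a 1.2-fold lower number from compound 1 to compound 4 (0.07 log units; within the scatter) and a 1.6-fold higher number from compound 2 to compound 4 (0.21 log units; within the scatter). A five-membered aromatic ring carrying one oxygen therefore fits the pattern so far, in which replacing phenethyl with an aromatic ring directly on the carbonyl carbon produces no step beyond the scatter, and the position accepts a drop from the eight heavy atoms of phenethyl to five without a clear change. Compound 3 now differs beyond the scatter from two of the amides, with a 2.2-fold lower number from compound 3 to compound 4 (0.35 log units; beyond the scatter) alongside the earlier difference from compound 2, although its step from compound 1 stays within the scatter, and no measurement available here accounts for these steps.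

The compounds shown leave open whether an amine, a carboxylic acid or a chain longer than phenethyl on this carbonyl carbon would move the number beyond the scatter from compound 1. They also leave open whether a thiophene ring would read like furan-2-yl, and whether any group here can take the series well below the values of compound 2 and compound 4.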